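Removing a Methylsulfanyl Group: Cytotoxicity in Skin Cells

The source may report more compounds than this note shows. Statements on the series, on what has been measured and on what is new or still open speak of the compounds shown alone.

Compound 1, `COc1cccc(/C=C/C(=O)c2c(OC)cc(OC)cc2OC)c1`, in a functional assay on HaCaT cells (Homo sapiens) for cytotoxicity, with a stated time of 48 h; a lower number here means a stronger inhibitor, a higher number a weaker inhibitor: 5300 nM
Compound 2, `COc1cc(OC)c(C(=O)/C=C/c2ccc(Cl)cc2)c(OC)c1`, in this assay: 7600 nM
Compound 3, `COc1cc(OC)c(C(=O)/C=C/c2ccccc2SC)c(OC)c1`, in this assay: 7700 nM

Compound 3 sits at the high end of these three numbers, yet its steps to the other two lie within the scatter: a 1.0-fold higher number from compound 2 to compound 3 (0.01 log units; within the scatter) and a 1.5-fold higher number from compound 1 to compound 3 (0.16 log units; within the scatter). Compound 4 `COc1cc(OC)c(C(=O)/C=C/c2ccccc2)c(OC)c1` differs from compound 3 by hydrogen in place of methylsulfanyl on an aromatic carbon. Going by the values given here, no measured step removes a group in this way; all three exchange one aryl group for another and none leaves the scatter, a 1.4-fold higher number from compound 1 to compound 2 (0.16 log units; within the scatter) included. Compound 4 is therefore expected to show no step beyond the scatter, a 1.1-fold lower number from compound 3 to compound 4 (0.04 log units; within the scatter). For compound 4 the estimated value in this assay is 7000 nM, with a range from 3500 nM to 14000 nM.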

Compound 4, half-maximal inhibitory concentration: 7200 nM
Compound 4: middle estimate off by 1.0-fold (0.01 log units), on the low side; low and high end bracket the measured number.
By their numbers in this assay, from the lowest: compounds 1, 4, 2 and 3 (each within the scatter of the next).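

Taking the substituent off the aryl group altogether keeps this assay within the scatter: hydrogen in place of methylsulfanyl gives a 1.1-fold lower number from compound 3 to compound 4 (0.03 log units; within the scatter), hydrogen in place of chloro gives a 1.1-fold lower number from compound 2 to compound 4 (0.02 log units; within the scatter), and hydrogen in place of methoxy gives a 1.4-fold higher number from compound 1 to compound 4 (0.13 log units; within the scatter). The earlier exchanges only set one substituted aryl group against another, whereas these steps show that none of the three substituents is separated from plain phenyl. Nothing available accounts for this result. From the compounds shown here alone, whether an amine or a carboxylic acid in place of methylsulfanyl would move the number beyond the scatter stays open.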